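Ring-closing the acyl branch of a pyrazole amide

The compounds below may be only part of what the source reports. "The series", "measured", "known", "first", "only" and "open" are said of these compounds alone.

Compound 1 `Cc1cc(C(=O)NC(C)C)nn1Cc1cc(Cl)ccc1OCc1ccccc1` gives 126 nM in an assay on CHO-K1 cells for displacement of a labelled ligand from prostaglandin E2 receptor EP1 subtype (Homo sapiens); on this read-out lower numbers stand for stronger inhibition and higher numbers for weaker inhibition.
Compound 2 `CC(=O)Nc1cc(C)n(Cc2cc(Cl)ccc2OCc2ccccc2)n1` gives 316 nM in this assay.
Compound 3 `Cc1cc(NC(=O)C(C)C)nn1Cc1cc(Cl)ccc1OCc1ccccc1` gives 25.1 nM in this assay.

Compound 3 stands lowest of the three in this assay, set apart from compound 1 by a 5.0-fold lower number from compound 1 to compound 3 (0.70 log units; beyond the scatter) and from compound 2 by a 13-fold lower number from compound 2 to compound 3 (1.10 log units; beyond the scatter). Compound 4 `Cc1cc(NC(=O)C2CCOCC2)nn1Cc1cc(Cl)ccc1OCc1ccccc1` differs from it in one place: oxan-4-yl in place of isopropyl on a carbonyl carbon. The step that bears on this is the growth of the acyl group, a 13-fold lower number from compound 2 to compound 3 (1.10 log units; beyond the scatter), which was large. Oxan-4-yl keeps that branched shape while adding a ring, so no further shift beyond the scatter is expected, and compound 4 is estimated at 20 nM (range 6 nM to 60 nM), a step of a 1.3-fold lower number from compound 3 to compound 4 (0.10 log units; within the scatter).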

Compound 4, half-maximal inhibitory concentration: 63.1 nM
Compound 4: the middle estimate sits 3.2-fold (0.50 log units) below what was measured; measured number outside the range, above it.
By their numbers in this assay, from the lowest: compound 3; then compounds 4 and 1 (each within the scatter of the next); then compound 2.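

In this assay, the carbonyl carbon does not treat every branched group alike: oxan-4-yl gives back part of what isopropyl gained (a 2.5-fold higher number from compound 3 to compound 4 (0.40 log units; beyond the scatter)), yet it still improves on methyl (a 5.0-fold lower number from compound 2 to compound 4 (0.70 log units; beyond the scatter)). The edge over the isopropylcarbamoyl compound also disappears (a 2.0-fold lower number from compound 1 to compound 4 (0.30 log units; within the scatter)). Nothing available explains the effect of the ring or its oxygen. Cyclohexyl, which would separate the ring from its oxygen, remains open. So do cyclopropyl and piperidin-4-yl, a smaller ring and a ring amine at this position.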